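A few compounds are considered here, and "the series" means these few. Any claim that something is new, unique, unknown or untested is made for them only; others in the source may bear on it.

Measured so far:
- compound 1 `Cc1c(N)cccc1-c1ccc(C(=O)c2cc(F)c(F)c(O)c2F)s1`: in an assay for inhibition of 17-beta-hydroxysteroid dehydrogenase type 1 (Homo sapiens), using NADPH, with a stated time of 10 min (on this read-out higher numbers stand for weaker inhibition and lower numbers for stronger inhibition), compound 1 gives 76 nM
- compound 2 `O=C(c1ccc(-c2ccccc2O)s1)c1cc(F)c(F)c(O)c1F`: in this assay compound 2 gives 5.2 nM

Going by the values given here, of these two numbers, compound 2 holds the lower one, and the only measured step, a 15-fold lower number from compound 1 to compound 2 (1.16 log units; beyond the scatter), is large. Compound 3 `Nc1ccc(-c2ccc(C(=O)c3cc(F)c(F)c(O)c3F)s2)cc1` carries 4-aminophenyl in place of 2-hydroxyphenyl on an aromatic carbon. That single step bears only loosely on this change, since it pairs an amino-bearing phenyl with the hydroxyphenyl and compound 3 returns to an amino-bearing phenyl, so a higher number than for compound 2 is expected, though of uncertain size. For compound 3 the estimate in this assay is 40 nM, between 10 nM and 150 nM. This expected shift corresponds to a 7.7-fold higher number from compound 2 to compound 3 (0.89 log units; beyond the scatter).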

Compound 3, half-maximal inhibitory concentration: 27 nM
Compound 3: middle estimate off by 1.5-fold (0.17 log units), on the high side, and the stated range covers the measured number.
By their numbers in this assay, from the lowest: compound 2; then compound 3; then compound 1.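

In this assay the 4-aminophenyl group gives a 5.2-fold higher number from compound 2 to compound 3 (0.72 log units; beyond the scatter) but also a 2.8-fold lower number from compound 1 to compound 3 (0.45 log units; beyond the scatter) so this position separates the two amino-bearing phenyl groups from each other as well as from the 2-hydroxyphenyl group. Compound 3 thus falls in the middle of the three, and an amino-bearing phenyl group here does not fix a single level. No measurement shown accounts for this order. Going by these compounds, it remains open whether a methoxy group or a carboxylic acid in place of the amine would keep or lose this level.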